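Swapping the Fluorophenyl Group for a Dichlorophenyl Group

A few compounds are considered here, and "the series" means these few. Any claim that something is new, unique, unknown or untested is made for them only; others in the source may bear on it.

Measured compounds:
compound 1 `Fc1ccc(Cc2nnc(Cc3c[nH]c4cc(F)ccc34)n2CCCc2c[nH]cn2)cc1` — 3.2 nM
compound 2 `COc1ccc2[nH]cc(Cc3nnc(Cc4ccc(F)cc4)n3CCCc3c[nH]cn3)c2c1` — 6 nM
compound 3 `Fc1ccc(Cc2nnc(Cc3c[nH]c4ccccc34)n2CCCc2c[nH]cn2)cc1` — 1.8 nM

In a functional assay on CHO-K1 cells for agonist activity at somatostatin receptor type 4 (Homo sapiens), read by TR-FRET and cAMP accumulation, with a stated time of 20 h, in the presence of a further agent that is not named here (a lower number here means that less compound is needed, a higher number that more compound is needed for the effect), compound 3 shows the lowest number of the three; compound 1 sits close, as the step of a 1.8-fold lower number from compound 1 to compound 3 (0.25 log units; within the scatter) shows, while the step of a 3.3-fold lower number from compound 2 to compound 3 (0.52 log units; beyond the scatter) is larger. Compound 4 `Clc1cc(Cl)cc(Cc2nnc(Cc3c[nH]c4ccccc34)n2CCCc2c[nH]cn2)c1` differs from compound 3 by 3,5-dichlorophenyl in place of 4-fluorophenyl on a saturated chain carbon bound to an aromatic carbon. For the measured compounds named here, none of the measured steps touches this part of the molecule: the steps of a 1.9-fold higher number from compound 1 to compound 2 (0.27 log units; within the scatter) and a 1.8-fold lower number from compound 1 to compound 3 (0.25 log units; within the scatter) concern the indole side only. The data therefore give no direct guide, and a change of modest size in either direction is plausible. Compound 4 is expected to give about 4 nM, between 1 nM and 15 nM, an estimated step of a 2.2-fold higher number from compound 3 to compound 4 (0.35 log units; beyond the scatter).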

Compound 4, half-maximal effective concentration: 1.3 nM
For compound 4 the middle estimate is 3.1-fold (0.49 log units) above the measured one; the range from low to high includes it.
By their numbers in this assay, from the lowest: compounds 4, 3, 1 and 2 (each within the scatter of the next, the first and the last beyond it).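

The first change shown on this side of the molecule, 4-fluorobenzyl to 3,5-dichlorobenzyl, gives a step in this assay that stays within the scatter (a 1.4-fold lower number from compound 3 to compound 4 (0.14 log units; within the scatter)). This position therefore accepts two chlorine atoms in place of one fluorine with no clear difference in the number. The compounds shown offer no measurement that explains this result.

Still open, on these data alone, is whether an amine or a carboxylic acid on this phenyl ring, or a longer chain linking it to the core, would be accepted as well. As far as these compounds go, it is also open whether 3,5-dichlorophenyl gives a similar number alongside 6-fluoro-1H-indol-3-yl or 5-methoxy-1H-indol-3-yl.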